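The compounds below may be only part of what the source reports. "The series", "measured", "known", "first", "only" and "open" are said of these compounds alone.

Of the compounds shown here, two have so far been measured in a functional assay on the whole organism (strain Wistar) for inhibition, with Rattus norvegicus as the target, read by paw edema, with a stated time of 3 h, at a dose of 10 mg/kg by the oral route; on this read-out higher numbers stand for more inhibition at the one dose given (going by the name of the read-out) and lower numbers for less inhibition. Compound 1 `Sc1nnc(COc2ccc(-c3ccccc3)cc2)n1-c1ccc(Cl)cc1` gives 15.9%. Compound 2 `Brc1ccc(Nc2nnc(COc3ccc(-c4ccccc4)cc3)s2)cc1` gives 63.6%, the higher of the two numbers, and its gap to compound 1 lies beyond the scatter of repeated runs. Compound 3 `Cc1ccc(Nc2nnc(COc3ccc(-c4ccccc4)cc3)s2)c(C)c1` has not yet been measured. It differs from compound 2 in one place: 2,4-dimethylphenyl in place of 4-bromophenyl on a nitrogen on an aromatic ring. Going by the values given here, no measured pair shows what this kind of exchange does here, so the step has to be judged without a direct precedent. Both compound 2 and compound 3 keep the same core and the same amino link; only the ring on that nitrogen changes. The expected step is modest and downward, within reach of the scatter: a number 13.6 percentage points lower from compound 2 to compound 3 (beyond the scatter). For compound 3 the estimated value in this assay is 50%, with a range from 30% to 70%.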

Compound 3, a percentage reported as inhibition, in the whole organism at one dose (the size of the read-out at that dose, not a potency): 56.8%
Beside the measured number, compound 3's estimate is 6.8 percentage points below it; the measured number falls inside the stated range.
By their numbers in this assay, from the lowest: compound 1; then compounds 3 and 2 (each within the scatter of the next).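

In this assay, the ring on this nitrogen can be exchanged without a shift that stands clear of the scatter: 2,4-dimethylphenyl in place of 4-bromophenyl gives a number 6.8 percentage points lower from compound 2 to compound 3 (within the scatter). For this pair, then, the bromine is not required to keep the read-out at the one dose given, and a ring carrying only carbon groups reads alike within the scatter. No measurement shown here gives a reason for this result.

The compounds shown leave open whether a plain phenyl, or a ring carrying an amine or a carboxylic acid, would hold the read-out at this place. They also leave open how compound 2 and compound 3 compare at other doses or at other times.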